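Notes on the aryl swap from compound 3 to compound 4

The source may hold more compounds than are shown below. What is called first, only, known or untested is meant among the compounds shown, and "the series" means these compounds.

Three measured compounds share one core and differ only in the aromatic ring attached to it. Compound 1 `CS(=O)(=O)c1ccc(-c2cnc3[nH]cc(-c4nnc(-c5cccnc5)o4)c(=O)c3c2)cc1` carries pyridin-3-yl there; in a functional assay on HCT-116 cells (Homo sapiens) for positive allosteric modulation, read by MTT assay, with stated times of 24 h and 48 h, tested at 2.5 uM (on this read-out higher numbers stand for more inhibition of growth at the one concentration tested and lower numbers for less inhibition of growth), compound 1 gives 28.6%. Compound 2 `CS(=O)(=O)c1ccc(-c2cnc3[nH]cc(-c4nnc(-c5ccc(F)cc5)o4)c(=O)c3c2)cc1` carries 4-fluorophenyl, and in this assay compound 2 gives 39.5%. Compound 3 `CS(=O)(=O)c1ccc(-c2cnc3[nH]cc(-c4nnc(-c5ccccc5)o4)c(=O)c3c2)cc1` carries plain phenyl, and in this assay compound 3 gives 27.2%, the lowest of the three numbers, although its gap to compound 1 is within the scatter, as a number 1.4 percentage points lower from compound 1 to compound 3 (within the scatter) shows. For the measured compounds named here, the only steps beyond the scatter involve the fluoro group: a number 10.9 percentage points higher from compound 1 to compound 2 (beyond the scatter) and a number 12.3 percentage points lower from compound 2 to compound 3 (beyond the scatter).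

Compound 4 `CS(=O)(=O)c1ccc(-c2cnc3[nH]cc(-c4nnc(-c5ccccn5)o4)c(=O)c3c2)cc1` differs from compound 3 in one place: pyridin-2-yl in place of phenyl on an aromatic carbon. The step that bears on this change is the earlier exchange of phenyl for pyridin-3-yl, a number 1.4 percentage points lower from compound 1 to compound 3 (within the scatter), which stayed within the scatter. On that basis no step beyond the scatter is expected in this assay in either direction, and a value close to compound 1 with 28.6% is as plausible as one close to compound 3. The expected step is a number 0.8 percentage points higher from compound 3 to compound 4 (within the scatter). For compound 4 the estimate is 28%, with a range from 18% to 40%.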

Compound 4, percent growth inhibition at one concentration: 34.3%
Beside the measured number, compound 4's estimate is 6.3 percentage points below it; measured number inside the range.
By their numbers in this assay, from the lowest: compounds 3, 1, 4 and 2 (each within the scatter of the next, the first and the last beyond it).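

In this assay, pyridin-2-yl at this position on the five-membered aromatic ring cannot be told apart from phenyl (a number 7.1 percentage points higher from compound 3 to compound 4 (within the scatter)), from pyridin-3-yl (a number 5.7 percentage points higher from compound 1 to compound 4 (within the scatter)) or from 4-fluorophenyl (a number 5.2 percentage points lower from compound 2 to compound 4 (within the scatter)). For the compounds shown here, compound 4 therefore fills the gap between compound 3 and compound 2, which were the only pair in this comparison beyond the scatter of each other, so with these four aryl groups 4-fluorophenyl no longer stands apart from every other group, and neither pyridine isomer can be separated from phenyl. No measurement at hand bears on why the numbers fall as they do.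

Still open, as far as these compounds go, is whether a group of another kind on this carbon, such as a saturated amine like piperidine or morpholine, or a phenyl ring carrying a carboxylic acid, would move the number beyond the scatter from compound 3. Also open is whether the small steps among these four aryl groups would persist at other concentrations, since each compound is represented here by a single reading at one concentration, which leaves full dose-response behaviour unknown.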